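Replacing 2-chlorophenyl with 4-(tert-butyl)phenyl at an assay limit

The source may report more compounds than this note shows. Statements on the series, on what has been measured and on what is new or still open speak of the compounds shown alone.

Measured in an ADME assay on L132 cells (Homo sapiens) for cytotoxicity, read by MTT assay, with a stated time of 48 h; a lower number here means a stronger inhibitor, a higher number a weaker inhibitor:
- Compound 1 `C/C(=C\CC/C(C)=C/CC[C@@H]1[C@@]2(C)CCC(=O)C(C)(C)[C@H]2CC[C@@]1(C)O)CC/C=C(\C)C(=O)OCc1cn(-c2cccc(C)c2)nn1`: > 150000 nM (a limit)
- Compound 2 `C/C(=C\CC/C(C)=C/CC[C@@H]1[C@@]2(C)CCC(=O)C(C)(C)[C@H]2CC[C@@]1(C)O)CC/C=C(\C)C(=O)OCc1cn(-c2ccccc2Cl)nn1`: > 150000 nM (a limit)

Compound 2 stands at > 150000 nM, which is a limit of the assay and not a number. Compound 1 stands at > 150000 nM, likewise a limit. The whole record in this assay is therefore this: the limit of > 150000 nM in this assay, at which 2 of the 2 values shown sit.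

Compound 3 `C/C(=C\CC/C(C)=C/CC[C@@H]1[C@@]2(C)CCC(=O)C(C)(C)[C@H]2CC[C@@]1(C)O)CC/C=C(\C)C(=O)OCc1cn(-c2ccc(C(C)(C)C)cc2)nn1` has 4-(tert-butyl)phenyl in place of 2-chlorophenyl on an aromatic nitrogen. Going by the values given here, the one measured step that bears on this change is a step that the two limits leave unreadable from compound 1 to compound 2, which also exchanges the group on an aromatic nitrogen. That step has no readable size, so no measured size or direction can be carried over to the new change, and none beyond the scatter is expected in this assay.

Since compound 2 offers only > 150000 nM, a limit, as its starting point, compound 3 is more likely than not to be reported as a limit too. The expected outcome is a number no higher from compound 2 to compound 3 (the limit leaves the size open), and this is an estimate only. For compound 3 the estimated value is 150000 nM, with an expected range of 60000 nM to 300000 nM.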

Compound 3, half-maximal inhibitory concentration: 65800 nM
For compound 3 the middle estimate is 2.3-fold (0.36 log units) above the measured one; the measured number falls inside the stated range.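

In this assay, the group on the aromatic nitrogen of the triazole-free description aside, the exchange now has a readable consequence: 4-(tert-butyl)phenyl in place of 2-chlorophenyl gives an at least 2.2-fold lower number from compound 2 to compound 3 (0.35 log units; beyond the scatter), and 4-(tert-butyl)phenyl in place of 3-methylphenyl gives an at least 2.2-fold lower number from compound 1 to compound 3 (0.35 log units; beyond the scatter). Going by these compounds alone, the earlier pair could show nothing about this position, and the step between those two compounds cannot be read, as both rest at one assay limit: the limit of > 150000 nM in this assay, at which 2 of the 3 values shown sit. Compound 3 is thus the only compound of the three with a number, and both new steps give only a least size, with the true distance left open by the limits at their starting points.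

The compounds shown do not separate the presence of the tert-butyl group from the place it occupies on the phenyl ring, or from the loss of chlorine, with the group count going from 7 to 10 heavy atoms in the same exchange. Going by these compounds, how the number would move with an amine or a carboxylic acid on that phenyl ring in place of tert-butyl also remains open.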